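Swapping Fluoro for Chloro on a Weakly Active Pair

The compounds below may be only part of what the source reports. "The series", "measured", "known", "first", "only" and "open" are said of these compounds alone.

Of the compounds shown here, two from this series have been measured for antiproliferative activity in an ADME assay on HaCaT cells (Homo sapiens) for antiproliferative activity, read by MTT assay, with a stated time of 48 h; on this read-out higher numbers stand for weaker inhibition and lower numbers for stronger inhibition. Compound 1 `O=C(/C=C\Nc1ccc(Cl)cc1)c1cn(-c2ccccc2)nc1-c1ccccc1` gives 28400 nM in this assay. Compound 2 `O=C(/C=C\Nc1ccc(F)cc1)c1cn(-c2ccccc2)nc1-c1ccc(F)cc1` gives only a limit of the assay in this assay, > 50000 nM, so its true value is not known; this is the situation described by the limit of > 50000 nM in this assay, at which 1 of the 2 values shown sits. On the numbers shown, compound 2 therefore stands at the weak end of the pair, with no measured step to compound 1.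

The next compound, compound 3 `O=C(/C=C\Nc1ccc(Cl)cc1)c1cn(-c2ccccc2)nc1-c1ccc(F)cc1`, differs from compound 2 by chloro in place of fluoro on an aromatic carbon. Among the measured compounds shown here, since no step between measured compounds links these two, the size of the change in this assay can only be guessed; the author expects a step of an at least 1.2-fold lower number from compound 2 to compound 3 (0.09 log units; that floor lies within the scatter) that stays within the usual scatter. Compound 3 is therefore estimated at 40000 nM, with a plausible range from 12000 nM to 120000 nM.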

Compound 3, half-maximal inhibitory concentration: 21300 nM
Estimate against measurement, compound 3: 1.9-fold (0.27 log units) above, within the range that was stated.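

In this assay, among the compounds shown here, chloro in place of fluoro in the (4-fluorophenyl)amino group gives an at least 2.3-fold lower number from compound 2 to compound 3 (0.37 log units; beyond the scatter), a step beyond the scatter at a position where the earlier compounds offered no step at all. For compound 2 the value is a limit of the assay, so this size is only a floor and the true step may be larger: the limit of > 50000 nM in this assay, at which 1 of the 3 values shown sits. The other change, fluoro in place of hydrogen on an aromatic carbon, gives a 1.3-fold lower number from compound 1 to compound 3 (0.12 log units; within the scatter), so with the chloro group in place it makes no difference that can be told from the scatter.

The compounds shown leave open how far the change at this position reaches, for instance with bromo, methyl or methoxy in place of chloro. They also leave open the true size of the step from fluoro to chloro.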